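This account rests on a few compounds, and the source may have more. Where it says the series, first, only, none or still open, it means among the compounds named here.

Measured compounds:
- compound 1 `Oc1ccc(-c2cc(-c3ccc(Cl)cc3)nc(-c3cccnc3)c2)cc1`: 22800 nM
- compound 2 `Oc1ccc(-c2cc(-c3ccc(Cl)cc3)nc(-c3cccs3)c2)cc1`: 7660 nM
- compound 3 `Oc1ccc(-c2cc(-c3cccc(Cl)c3)nc(-c3cccs3)c2)cc1`: 5740 nM

All three were tested in a functional assay on DU-145 cells (Homo sapiens) for cytotoxicity, read by CCK-8 assay and cell counting, with a stated time of 2 days; a higher number here means a weaker inhibitor, a lower number a stronger inhibitor. Compound 2 stands between the other two. Its value and that of compound 3 lie within the usual scatter of each other, as the step of a 1.3-fold lower number from compound 2 to compound 3 (0.13 log units; within the scatter) shows, so no real difference can be claimed there. Compound 1 is further away: the step of a 3.0-fold lower number from compound 1 to compound 2 (0.47 log units; beyond the scatter) lies beyond the scatter.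

Compound 4 `Oc1ccc(-c2cc(-c3ccccc3)nc(-c3ccc(Cl)cc3)c2)cc1` differs from compound 2 in one place: phenyl in place of thiophen-2-yl on an aromatic carbon. Among the measured compounds shown here, the only measured step that touches this position is the one from compound 1 to compound 2, where a five-membered ring with sulfur replaced a six-membered ring with nitrogen and gave a modest step. Here a six-membered ring of carbon only replaces the five-membered ring. For the measured compounds named here, with no step of this exact kind measured, a change of no more than modest size is expected in this assay, in either direction. Compound 4 is therefore estimated at 6000 nM, with a range from 2500 nM to 15000 nM, which amounts to an expected step of a 1.3-fold lower number from compound 2 to compound 4 (0.11 log units; within the scatter).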

Compound 4, half-maximal inhibitory concentration: 7270 nM
Compound 4: middle estimate off by 1.2-fold (0.08 log units), on the low side, and the stated range covers the measured number.
By their numbers in this assay, from the lowest: compounds 3, 4 and 2 (each within the scatter of the next); then compound 1.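

In this assay, thiophen-2-yl and phenyl cannot be told apart at this aromatic carbon (a 1.1-fold lower number from compound 2 to compound 4 (0.02 log units; within the scatter)), so the change from a five-membered ring with sulfur to a six-membered ring of carbon only makes no measurable difference here. Compound 1 now stands apart from both, since phenyl also differs from pyridin-3-yl (a 3.1-fold lower number from compound 1 to compound 4 (0.50 log units; beyond the scatter)), a modest step in the same direction as the one from pyridin-3-yl to thiophen-2-yl, so among these three groups only pyridin-3-yl goes with the higher number. No measurement is available to explain why these groups compare as they do.

All three groups are flat aromatic rings, so the compounds shown leave open how a saturated ring such as cyclohexyl would fare at this carbon. They also leave open what a small group, such as an amine or a carboxylic acid, would do there.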